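Urea aryl substitution in a quinoline ether series

The compounds below may be only part of what the source reports. "The series", "measured", "known", "first", "only" and "open" are said of these compounds alone.

Within the data shown here, compound 1 `COc1cc2cc(Oc3ccc(NC(=O)Nc4ccccc4)cc3)c(C)nc2cc1OC` gives 67.2% in a functional assay on NCI-H522 cells (Homo sapiens) for inhibition, read by sulforhodamine B assay, with a stated time of 48 h, tested at 10 uM (a higher number here means a weaker effect of the compound at the concentration tested, a lower number a stronger effect), the second highest of the three numbers so far. Compound 2 `COc1cc2cc(Oc3ccc(NC(=O)Nc4ccc(C)cc4)cc3)c(C)nc2cc1OC` gives 69.9%, and the step of a number 2.7 percentage points higher from compound 1 to compound 2 (within the scatter) stays within the scatter. Compound 3 `COc1cc2cc(Oc3ccc(NC(=O)Nc4cccc(C(F)(F)F)c4)cc3)c(C)nc2cc1OC` gives -17.4%; the step of a number 84.6 percentage points lower from compound 1 to compound 3 (beyond the scatter) is large, as is a number 87.3 percentage points lower from compound 2 to compound 3 (beyond the scatter). Compound 4 `COc1cc2cc(Oc3ccc(NC(=O)Nc4ccc(Cl)c(C(F)(F)F)c4)cc3)c(C)nc2cc1OC` differs from compound 1 by 4-chloro-3-(trifluoromethyl)phenyl in place of phenyl on an amide-type nitrogen. The step from compound 1 to compound 3 bears directly on this change, since compound 4 carries the same trifluoromethyl group together with a chlorine; the methyl step from compound 1 to compound 2 shows nothing. A large drop is therefore expected, a number 79.2 percentage points lower from compound 1 to compound 4 (beyond the scatter), close to the drop seen for compound 3. Compound 4 is estimated at -12%, within -45% to 30%.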

Compound 4, a percentage reported as activity, at one concentration (the size of the read-out at that concentration, not a potency): -43.6%
Compound 4: middle estimate off by 31.6 percentage points, on the high side; the measured number falls inside the stated range.
By their numbers in this assay, from the lowest: compound 4; then compound 3; then compounds 1 and 2 (each within the scatter of the next).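

Chloro on the trifluoromethyl-bearing phenyl pushes the number further down in this assay, a number 26.2 percentage points lower from compound 3 to compound 4 (beyond the scatter), so the effect of substitution on this amide-type nitrogen's aryl group had not bottomed out at compound 3. With 4-chloro-3-(trifluoromethyl)phenyl the drop is large against either simpler aryl group: a number 110.8 percentage points lower from compound 1 to compound 4 (beyond the scatter), and a number 113.5 percentage points lower from compound 2 to compound 4 (beyond the scatter). No measurement at hand explains the added effect of the chlorine.

On these data alone, whether chloro alone, without trifluoromethyl, lowers the number remains open. So does whether a nitrile or a dimethylamino group on the same phenyl would do the same.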